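A few compounds are considered here, and "the series" means these few. Any claim that something is new, unique, unknown or untested is made for them only; others in the source may bear on it.

Measured so far:
- compound 1, `COc1ccc(COCC(Cn2ccnc2)OCc2ccc(OC)cc2)cc1`: 9900 nM
- compound 2, `COC(=O)c1ccc(COC(COCc2ccc(OC)cc2)Cn2ccnc2)cc1`: 1260 nM
- compound 3, `COc1ccc(COCC(Cn2ccnc2)OCc2ccc(C(=O)Oc3ccccc3)cc2)cc1`: 560 nM

Read-out throughout is a functional assay for inhibition of Thromboxane-A synthase (Homo sapiens); a higher number here means a weaker inhibitor, a lower number a stronger inhibitor. Compound 3 stands lowest of the three numbers in this assay; its nearest neighbour is compound 2, and compound 1 is furthest away. The two steps out of compound 1, a 7.9-fold lower number from compound 1 to compound 2 (0.90 log units; beyond the scatter) and an 18-fold lower number from compound 1 to compound 3 (1.25 log units; beyond the scatter), show that the ester in place of the methoxy on that aromatic carbon moves the number substantially. The step within the ester series, a 2.3-fold lower number from compound 2 to compound 3 (0.35 log units; beyond the scatter), is the one that bears directly on the next change, and it is modest.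

Compound 4, `COc1ccc(COCC(Cn2ccnc2)OCc2ccc(C(=O)OCc3ccccc3)cc2)cc1`, differs from compound 3 by benzyl in place of phenyl on an oxygen next to a carbonyl group. Going by the values given here, only the step from compound 2 to compound 3 informs this position, and it was modest; the change from phenyl to benzyl is smaller than that from methyl to phenyl. The expected step in this assay is therefore small, of uncertain direction, and may well fall within the scatter. For compound 4 the expected value is 500 nM, with a range from 180 nM to 1400 nM. This amounts to an expected step of a 1.1-fold lower number from compound 3 to compound 4 (0.05 log units; within the scatter).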

Compound 4, half-maximal inhibitory concentration: 1490 nM
For compound 4 the middle estimate is 3.0-fold (0.47 log units) below the measured one; measured number above the stated range.
By their numbers in this assay, from the lowest: compound 3; then compounds 2 and 4 (each within the scatter of the next); then compound 1.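

In this assay, benzyl in place of phenyl on an oxygen next to a carbonyl group gives a 2.7-fold higher number from compound 3 to compound 4 (0.42 log units; beyond the scatter), so the advantage of phenyl over methyl at this oxygen does not extend to benzyl. The benzyl and methyl esters are not separated, with a 1.2-fold higher number from compound 2 to compound 4 (0.07 log units; within the scatter), which leaves compound 3 alone in standing apart among the esters. The difference from the methoxy group persists with benzyloxycarbonyl, at a 6.6-fold lower number from compound 1 to compound 4 (0.82 log units; beyond the scatter). No independent data bear on why phenyl and benzyl differ at this position.

Still open, going by these compounds, is how far this position tolerates a longer chain, such as phenethyl, on the same oxygen. On these data alone, it is also open whether the ester link itself matters, which an amide or a carboxylic acid in place of the ester would test.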